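This account rests on a few compounds, and the source may have more. Where it says the series, first, only, none or still open, it means among the compounds named here.

Measured so far in an ADME assay on Vero cells (Chlorocebus sabaeus) for cytotoxicity, with a stated time of 72 h; on this read-out lower numbers stand for stronger inhibition and higher numbers for weaker inhibition:

compound 1 `O=[N+]([O-])c1cn2c(n1)OC[C@@H](OCc1ccc(-c3ccc(C(F)(F)F)cc3)s1)C2` — in this assay compound 1 gives > 128000 nM, which is a limit of the assay.
compound 2 `O=[N+]([O-])c1cn2c(n1)OC[C@@H](OCc1ccc(-c3ccc(F)cc3)s1)C2` — in this assay compound 2 gives > 128000 nM, a limit.
compound 3 `O=[N+]([O-])c1cn2c(n1)OC[C@@H](OCc1cnn(-c3ccc(C(F)(F)F)cc3)c1)C2` — in this assay compound 3 gives > 128000 nM, a limit.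

Compound 1 and compound 2 differ by fluoro in place of trifluoromethyl on an aromatic carbon. The step that the two limits leave unreadable from compound 1 to compound 2 cannot be read, because the limit of > 128000 nM in this assay, at which 3 of the 3 values shown sit, holds both ends. The difference between the core of compound 1 and the core of compound 3 is not broken down here.

Compound 4 `O=[N+]([O-])c1cn2c(n1)OC[C@@H](OCc1cnn(-c3ccc(F)cc3)c1)C2` stands to compound 3 as compound 2 stands to compound 1: the change is fluoro in place of trifluoromethyl on an aromatic carbon, the same change at the same kind of place. For the measured compounds named here, the step that the limit leaves unreadable from compound 3 to compound 4 is therefore expected to be no more readable than the earlier one, since every value so far sits at the limit of > 128000 nM in this assay, at which 3 of the 3 values shown sit. For compound 4 the expected value is 200000 nM, most likely again reported as a limit.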

Compound 4, half-maximal inhibitory concentration: > 128000 nM
Compound 4 ended at the assay's limit; the forecaster's own chance of this, stated with the estimate: 90%; the middle value is on the limit's open side.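

No step can be read from compound 3 to compound 4 in this assay, because both values are limits: the limit of > 128000 nM in this assay, at which 4 of the 4 values shown sit.

As far as these compounds go, whether compound 1, compound 2, compound 3 and compound 4 differ at all in this assay remains open, as does any effect of the core or of fluoro in place of trifluoromethyl.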